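This account rests on a few compounds, and the source may have more. Where it says the series, first, only, none or still open, it means among the compounds named here.

Measured so far in a functional assay on DU-145 cells (Homo sapiens) for inhibition, read by trypan blue exclusion, with a stated time of 96 h; a lower number here means a stronger inhibitor of growth, a higher number a weaker inhibitor of growth:
compound 1 `O=C(/C(=C\c1ccc(F)c([N+](=O)[O-])c1)SCc1ccc(F)cc1)c1ccc(F)cc1` — 1000 nM
compound 2 `O=C(/C(=C\c1cc(Cl)c(O)c(Cl)c1)S(=O)(=O)Cc1ccc(Br)cc1)c1ccc(Br)cc1` — 25000 nM
compound 3 `O=C(/C(=C\c1ccc(O)c([N+](=O)[O-])c1)SCc1ccc(Br)cc1)c1ccc(O)cc1O` — > 100000 nM, a limit of the assay, not a number

Compound 3 therefore stands at the edge of what this assay reports; (the limit of > 100000 nM in this assay, at which 1 of the 3 values shown sits). Going by the values given here, no pair of measured compounds differs in a single place, so no measured step is known in this assay.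

Compound 4 `O=C(/C(=C\c1ccc(O)c([N+](=O)[O-])c1)SCc1ccc(Br)cc1)c1ccc([N+](=O)[O-])cc1` is not yet measured. It differs from compound 3 at one place: 4-nitrophenyl in place of 2,4-dihydroxyphenyl on a carbonyl carbon.

Since compound 3 sits at a limit, a lower number for compound 4 is not excluded, and a number beyond the scatter is expected in that direction for the step from compound 3 to compound 4: an at least 3.3-fold lower number from compound 3 to compound 4 (0.52 log units; beyond the scatter). Compound 4 is expected at 30000 nM, within 5000 nM to 100000 nM.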

Compound 4, concentration for 50% growth inhibition: 10000 nM
Compound 4: middle estimate off by 3.0-fold (0.48 log units), on the high side; the range from low to high includes it.
By their numbers in this assay, from the lowest: compound 1; then compound 4; then compound 2. At a limit, above all of these: compound 3.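

In this assay the group on the carbonyl carbon now has its first measured step, and the position is not silent: 4-nitrophenyl in place of 2,4-dihydroxyphenyl gives an at least 10-fold lower number from compound 3 to compound 4 (1.00 log units; beyond the scatter), with compound 4 as a measurable inhibitor of growth. For compound 3, > 100000 nM is a limit of the assay, not a number. On these data alone, the step therefore fixes only a minimum size, and its full size remains unknown: the limit of > 100000 nM in this assay, at which 1 of the 4 values shown sits.

The compounds shown do not separate the loss of the two hydroxyl groups from the entry of the nitro group. Where an unsubstituted phenyl, a 4-aminophenyl or a 4-carboxyphenyl on this carbonyl carbon would fall also stays open.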